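Cyanophenyl for Fluorophenyl on Two Urea Cores

The compounds below may be only part of what the source reports. "The series", "measured", "known", "first", "only" and "open" are said of these compounds alone.

Measured compounds:
Compound 1 `Cc1ccc(CN2CCC(NC(=O)NCc3ccc(-c4ccc(F)cc4)cc3)CC2)cc1` gives 198 nM
Compound 2 `Cc1ccc(CN2CCC(NC(=O)NCc3ccc(-c4cccc(C#N)c4)cc3)CC2)cc1` gives 411 nM
Compound 3 `Cc1ccc(CN2CCC(CCN(Cc3ccc(-c4ccc(F)cc4)cc3)C(=O)NC(C)(C)CO)CC2)cc1` gives 41.4 nM

All three were tested in an in vitro functional assay on HEK293 cells for antagonist activity at melanin-concentrating hormone receptor 1 (Homo sapiens), read by GTPgammaS binding, with a stated time of 45 min; on this read-out higher numbers stand for weaker inhibition and lower numbers for stronger inhibition. Compound 1 and compound 2 share one core and differ by a single change, (3-cyanophenyl in place of 4-fluorophenyl on an aromatic carbon), which produced a 2.1-fold higher number from compound 1 to compound 2 (0.32 log units; beyond the scatter). Compound 3 rests on a different core; how its core differs from the core of compound 1 is not broken down here. Among the three, compound 3 has the lowest number, and its steps to compound 1 and compound 2 both lie beyond the scatter.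

Compound 4 `Cc1ccc(CN2CCC(CCN(Cc3ccc(-c4cccc(C#N)c4)cc3)C(=O)NC(C)(C)CO)CC2)cc1` is compound 3 carrying the change (3-cyanophenyl in place of 4-fluorophenyl on an aromatic carbon). This is the same change as from compound 1 to compound 2, at the same kind of position, and it occurs twice among these compounds. Among the compounds with values here, for compound 4 in this assay a step of a 2.1-fold higher number from compound 3 to compound 4 (0.31 log units; beyond the scatter) is expected, set beside a 2.1-fold higher number from compound 1 to compound 2 (0.32 log units; beyond the scatter), because a 2.1-fold higher number from compound 1 to compound 2 (0.32 log units; beyond the scatter) is the only measured example of this change. The value of compound 4 is estimated at 85 nM. The expected range for compound 4 runs from 45 nM to 170 nM.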

Compound 4, antagonist equilibrium constant: 84 nM
For compound 4 the middle estimate is 1.0-fold (0.01 log units) above the measured one, and the stated range covers the measured number.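

In this assay, putting 3-cyanophenyl in place of 4-fluorophenyl on the second core gave a 2.0-fold higher number from compound 3 to compound 4 (0.31 log units; beyond the scatter), a modest step in the same direction as the one seen on the first core. In this series the change therefore carried from one core to the other with its size preserved: the same change on two cores in this assay, a 2.1-fold higher number (0.32 log units; beyond the scatter) from compound 1 to compound 2 and a 2.0-fold higher number (0.31 log units; beyond the scatter) from compound 3 to compound 4, 1.0-fold (0.01 log units) apart, within the scatter of two such steps

Within the data shown here, this agreement rests on only two pairs of compounds and a single exchange of groups, so it shows that the step held on these two cores, but it does not establish a general rule for other cores and does not explain why the two steps match.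

The compounds shown leave open whether a step of this size would recur on a third core, for example one with a longer chain in place of the ethyl link in compound 3. They also leave open how a methoxy group, an amine or a carboxylic acid in place of the nitrile would behave on either core.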